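A few compounds are considered here, and "the series" means these few. Any claim that something is new, unique, unknown or untested is made for them only; others in the source may bear on it.

Working notes on the series. Compound 1 `CN(CCCn1cc[n+](C)c1/C=N/O)S(C)(=O)=O` is the most polar member: in a physicochemical assay for lipophilicity (a lower number here means a more polar compound, a higher number a more lipophilic compound), compound 1 gives -2.63. Compound 2 `CN(CCCn1cc[n+](C)c1/C=N/O)S(=O)(=O)C(F)(F)F` carries trifluoromethyl in place of methyl on the sulfonyl sulfur, and in this assay compound 2 gives -1.37; the step is a number 1.26 log units higher from compound 1 to compound 2 (beyond the scatter). Compound 3 `C[n+]1ccn(CCCNS(=O)(=O)c2ccccc2)c1/C=N/O` sits second highest of the three numbers: in this assay compound 3 gives -1.89, which lies beyond the scatter above the value of compound 1 and beyond the scatter below the value of compound 2.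

Compound 4 `CN(CCCn1cc[n+](C)c1/C=N/O)S(=O)(=O)c1ccccc1` differs from compound 3 by methyl in place of hydrogen on a sulfonamide nitrogen. Among the measured compounds shown here, no measured step touches the sulfonamide nitrogen; the only step in hand concerns the sulfonyl sulfur and is not a guide to this change. The expectation for compound 4 therefore rests on the value of compound 3 alone, with a small upward step, about the edge of the scatter, judged plausible. Compound 4 is estimated at -1.6 in this assay, within -2 to -1.2. The expected step is a number 0.29 log units higher from compound 3 to compound 4 (within the scatter).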

Compound 4, distribution coefficient: -1.59
Estimate against measurement, compound 4: 0.01 log units below; low and high end bracket the measured number.
By their numbers in this assay, from the lowest: compound 1; then compounds 3, 4 and 2 (each within the scatter of the next, the first and the last beyond it).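

In this assay, among the compounds shown here, methyl in place of hydrogen on a sulfonamide nitrogen gives a number 0.30 log units higher from compound 3 to compound 4 (within the scatter), the first reading at this position, and that step stays within the scatter for this pair. On the sulfonyl sulfur, with the nitrogen carrying methyl, phenyl in place of trifluoromethyl gives a number 0.22 log units lower from compound 2 to compound 4 (within the scatter), whereas phenyl in place of methyl gives a number 1.04 log units higher from compound 1 to compound 4 (beyond the scatter), so in this pair set only the methyl compound stands apart. No supporting data on hand speak to the origin of these steps.

The compounds shown leave open whether methyl in place of hydrogen on a sulfonamide nitrogen gives a like step when the sulfonyl sulfur carries methyl or trifluoromethyl instead of phenyl. Also open, as far as these compounds go, is where a longer chain on that nitrogen, or an amine or a carboxylic acid on the phenyl, would stand in this assay.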